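A few compounds are considered here, and "the series" means these few. Any claim that something is new, unique, unknown or untested is made for them only; others in the source may bear on it.

In an ADME assay on the whole organism (Mus musculus, strain Swiss Webster) for pharmacokinetics, read by LC-MS, at a dose of 50 mg/kg by the oral route (a lower number here means less compound in the circulation, a higher number more compound in the circulation at the dose given), compound 1 `O=C(Nc1ccc(F)c(-c2nc3ncc(-c4ccc(F)cc4F)cc3[nH]2)c1)N1CCCC1` gives 15600 ng.h/mL, compound 2 `O=C(Nc1ccc(F)c(-c2nc3ncc(-c4ccc(F)cc4)cc3[nH]2)c1)N1CCCC1` gives 10200 ng.h/mL and compound 3 `O=C(Nc1ccc(F)c(-c2nc3ncc(-c4cccc(F)c4F)cc3[nH]2)c1)N1CCCC1` gives 4750 ng.h/mL, the lowest of the three numbers. Compound 4 `O=C(Nc1ccc(F)c(-c2nc3ncc(-c4cccnc4F)cc3[nH]2)c1)N1CCCC1` carries 2-fluoropyridin-3-yl in place of 2,3-difluorophenyl on an aromatic carbon. The measured steps that bear on this change also exchange the group on that carbon. Of these, a 1.5-fold lower number from compound 1 to compound 2 (0.18 log units; within the scatter) stays within the scatter, while a 3.3-fold lower number from compound 1 to compound 3 (0.52 log units; beyond the scatter) and a 2.1-fold lower number from compound 2 to compound 3 (0.33 log units; beyond the scatter) are modest. None of them swaps a ring carbon for a ring nitrogen, so they indicate no direction. The expected step is a 1.1-fold higher number from compound 3 to compound 4 (0.02 log units; within the scatter), which means no change beyond the scatter is anticipated. Compound 4 is estimated at 5000 ng.h/mL, within an expected range of 1800 ng.h/mL to 13000 ng.h/mL.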

Compound 4, area under the concentration-time curve: 30900 ng.h/mL
Compound 4: the middle estimate sits 6.2-fold (0.79 log units) below what was measured; measured number outside the range, above it.
By their numbers in this assay, from the lowest: compound 3; then compounds 2, 1 and 4 (each within the scatter of the next, the first and the last beyond it).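

In this assay, going by these compounds alone, replacing 2,3-difluorophenyl with 2-fluoropyridin-3-yl, the only ring here with a hetero atom on this aromatic carbon, gives a 6.5-fold higher number from compound 3 to compound 4 (0.81 log units; beyond the scatter), the largest step at this position so far. The same group gives a 3.0-fold higher number from compound 2 to compound 4 (0.48 log units; beyond the scatter) against 4-fluorophenyl, but a 2.0-fold higher number from compound 1 to compound 4 (0.30 log units; within the scatter) against 2,4-difluorophenyl, so it stands clear of only two of the three phenyl groups. Nothing available here accounts for the rise. Going by these compounds, whether an unsubstituted pyridin-3-yl or a pyrimidin-5-yl group on this carbon would give a similar number remains open.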